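The compounds below may be only part of what the source reports. "The series", "measured", "known", "first", "only" and "open" are said of these compounds alone.

Measured compounds in an ADME assay on SW480 cells (Homo sapiens) for cytotoxicity, read by MTT assay, with a stated time of 72 h; a higher number here means a weaker inhibitor, a lower number a stronger inhibitor:

compound 1 `CCOc1ccc(NC(=O)c2cccc(/C=C3\CC(=O)N(Cc4ccccc4)C3=O)c2)cc1`: 73200 nM
compound 2 `O=C(NCC1CCCCC1)c1cccc(/C=C2\CC(=O)N(c3ccccc3)C2=O)c1`: the assay gives only a limit, > 100000 nM
compound 3 `CCOc1ccc(NC(=O)c2cccc(/C=C3\CC(=O)N(c4ccccc4)C3=O)c2)cc1`: 91500 nM

Compound 1 holds the lowest of the two numbers; its nearest neighbour is compound 3, with a 1.3-fold higher number from compound 1 to compound 3 (0.10 log units; within the scatter). Compound 2 returns only a limit, (the limit of > 100000 nM in this assay, at which 1 of the 3 values shown sits). From compound 2 to compound 3 the change on the amide-type nitrogen gives an at least 1.0-fold lower number from compound 2 to compound 3 (0.03 log units; that floor lies within the scatter).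

Compound 4 `CCc1cccc(NC(=O)c2cccc(/C=C3\CC(=O)N(Cc4ccccc4)C3=O)c2)c1` is compound 1 with one change: 3-ethylphenyl in place of 4-ethoxyphenyl on an amide-type nitrogen. The step from compound 2 to compound 3 is the only one that alters this same amide-type nitrogen, and it stayed at the floor of the scatter; the step from compound 1 to compound 3 changes a different site and also stays within the scatter. On that basis no step beyond the scatter is expected from compound 1 to compound 4 in this assay, a 1.1-fold higher number from compound 1 to compound 4 (0.04 log units; within the scatter). Compound 4 is therefore estimated at 80000 nM, with a range from 40000 nM to 160000 nM.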

Compound 4, half-maximal inhibitory concentration: 91500 nM
Compound 4: middle estimate off by 1.1-fold (0.06 log units), on the low side; the measured number falls inside the stated range.
By their numbers in this assay, from the lowest: compounds 1, 3 and 4 (each within the scatter of the next). At a limit, above all of these: compound 2.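

In this assay, 3-ethylphenyl in place of 4-ethoxyphenyl on the amide-type nitrogen gives a 1.3-fold higher number from compound 1 to compound 4 (0.10 log units; within the scatter). Unlike the earlier step at this nitrogen, which started from a limit, this one has a full number at both ends, and it shows that the group can lose its ethoxy oxygen, the one hydrogen-bond acceptor counted in 4-ethoxyphenyl, without a change beyond the scatter. The data shown give no reason for this flat step.

Still open, on these data alone, is whether any group on this nitrogen moves the number beyond the scatter, for instance a phenyl ring carrying a carboxylic acid or an amine. With only these two substituted phenyl groups compared directly, the separate contributions of the ethyl or ethoxy group and of its place on the ring also cannot be told apart.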